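A Methyl Group Added to a Level Series

The compounds below may be only part of what the source reports. "The series", "measured", "known", "first", "only" and "open" are said of these compounds alone.

Compound 2 `Cc1noc(C)c1-c1ccc2c(c1)c(Cc1ccccc1)cn2CCCCCCC(=O)NO` gives 15500 nM in a functional assay on THP-1 cells (Homo sapiens) for inhibition (on this read-out lower numbers stand for stronger inhibition of growth and higher numbers for weaker inhibition of growth), level with compound 1 `Cc1noc(C)c1-c1ccc2c(c1)c(Cc1ccccc1)cn2CCCCCC(=O)NO` at 15500 nM and compound 3 `Cc1noc(C)c1-c1ccc2c(c1)c(Cc1ccc(F)cc1)cn2CCCCCC(=O)NO` at 15500 nM in the same read-out. Compound 4 `Cc1cccc(Cc2cn(CCCCCCC(=O)NO)c3ccc(-c4c(C)noc4C)cc23)c1` differs from compound 2 by a single change, methyl in place of hydrogen on an aromatic carbon (methyl in place of hydrogen on an aromatic carbon, turning benzyl into 3-methylbenzyl). No methyl on this ring has been measured yet, so the evidence is indirect. The closest measured change is fluoro in place of hydrogen on an aromatic carbon, which gave no change at the digits printed from compound 1 to compound 3 (within the scatter) and so moved nothing beyond the scatter. The other measured change, (hydroxycarbamoyl)methyl in place of hydroxycarbamoyl, gave no change at the digits printed from compound 1 to compound 2 (within the scatter) and also stayed within the scatter. With both steps this small, the expected step of no change at the digits printed from compound 2 to compound 4 (within the scatter) stays within the scatter in this assay with no direction favoured. Compound 4 is estimated at 15500 nM within a range of 9000 nM to 25000 nM in this read-out.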

Compound 4, concentration for 50% growth inhibition: 15500 nM
The estimate for compound 4 equals the measured number at the digits printed; the measured number falls inside the stated range.
By their numbers in this assay, from the lowest: compounds 1, 2, 3 and 4 (each within the scatter of the next).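

In this assay, methyl in place of hydrogen on the aromatic ring, turning benzyl into 3-methylbenzyl, gives no change at the digits printed from compound 2 to compound 4 (within the scatter). Among the compounds shown here, this is the first reading of a carbon group on this ring, which had so far carried only fluoro, and that on the chain of compound 1. All four compounds now sit level, so this change joins the other two as a step that leaves the read-out where it was, and nothing measured here bears on why.

On these data alone, whether an amine or a carboxylic acid on this ring would also leave the number level stays open. With every value level, the compounds shown also leave open which part of the structure, if any, this read-out responds to.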